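Methoxy shift from compound 3 to compound 4

This account rests on a few compounds, and the source may have more. Where it says the series, first, only, none or still open, it means among the compounds named here.

Going by the values given here, in an ADME assay on Caco-2 cells (Homo sapiens) for permeability, read by LC-MS, in the apical to basolateral direction, with a stated time of 2 h, tested at 2 uM (on this read-out higher numbers stand for higher permeability and lower numbers for lower permeability), compound 3 (`CC[C@@H](Nc1c(C#N)c(-c2ccc(-c3ccccc3OC)cc2)nc2cnccc12)C(N)=O`) gives 160 nm/s, the highest of three numbers so far. Compound 1 (`CC[C@@H](Nc1c(C#N)c(-c2ccc(-c3cccc(C)c3F)cc2)nc2cnccc12)C(N)=O`) gives 47 nm/s, and compound 2 (`CC[C@@H](Nc1c(C#N)c(-c2ccc(-c3ccc(Cl)cc3)cc2)nc2cnccc12)C(N)=O`) gives 29 nm/s. Compound 4 (`CC[C@@H](Nc1c(C#N)c(-c2ccc(-c3cccc(OC)c3)cc2)nc2cnccc12)C(N)=O`) differs from compound 3 at one place: 3-methoxyphenyl in place of 2-methoxyphenyl on an aromatic carbon. The new 3-methoxyphenyl stays on an aromatic carbon, para to a large group.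

All three measured steps are exchanges at this place. Two are modest and beyond the scatter: a 3.4-fold higher number from compound 1 to compound 3 (0.53 log units; beyond the scatter) and a 5.5-fold higher number from compound 2 to compound 3 (0.74 log units; beyond the scatter). The third, a 1.6-fold lower number from compound 1 to compound 2 (0.21 log units; within the scatter), stays within it. Among the compounds with values here, no measured pair moves a group around the same ring, so the data do not test this change directly. Only compound 3 carries 2-methoxyphenyl, and its high number may not carry over to the isomer. A modest fall in this assay is therefore expected, towards compound 1 and compound 2. The expected change is a 2.3-fold lower number from compound 3 to compound 4 (0.36 log units; beyond the scatter). For compound 4 the estimate is 70 nm/s, with an expected range of 25 nm/s to 190 nm/s.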

Compound 4, apparent permeability: 104 nm/s
Compound 4: the middle estimate sits 1.5-fold (0.17 log units) below what was measured; the range from low to high includes it.
By their numbers in this assay, from the lowest: compounds 2 and 1 (each within the scatter of the next); then compounds 4 and 3 (each within the scatter of the next).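

The methoxy group has now been moved on this ring, and in this assay the change is a 1.5-fold lower number from compound 3 to compound 4 (0.19 log units; within the scatter), so the number of compound 3 is not unique to 2-methoxyphenyl. The 3-methoxyphenyl isomer also stands clear of the other two aryl groups, with a 3.6-fold higher number from compound 2 to compound 4 (0.55 log units; beyond the scatter) and a 2.2-fold higher number from compound 1 to compound 4 (0.34 log units; beyond the scatter), and among these four compounds both methoxyphenyl groups therefore sit above 4-chlorophenyl and 2-fluoro-3-methylphenyl. Nothing measured on these compounds accounts for this grouping.

As far as these compounds go, it remains open whether the grouping extends to an ethoxy group, a hydroxyl or a dimethylamino group at this place. Also open, from the compounds shown here alone, is whether it survives a change elsewhere, such as a carboxylic acid in place of the primary amide.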